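The source may hold more compounds than are shown below. What is called first, only, known or untested is meant among the compounds shown, and "the series" means these compounds.

Of the compounds shown here, three built on one shared core have been measured. Compound 1 `COc1cc2c(/C=C3/C(=O)Nc4ccc(O)cc43)c(Cl)n(Cc3cc(OC)c(OC)c(OC)c3)c2cc1C` gives 2290 nM in a functional assay on cells (Cancer cell lines, Homo sapiens) for cytotoxicity, with a stated time of 48 h (on this read-out lower numbers stand for stronger inhibition of growth and higher numbers for weaker inhibition of growth), and compound 2 `COc1cc2c(/C=C3/C(=O)Nc4ccc(Cl)cc43)c(Cl)n(Cc3cc(OC)c(OC)c(OC)c3)c2cc1C` gives 2190 nM. Among the compounds with values here, the one step between them, a 1.0-fold lower number from compound 1 to compound 2 (0.02 log units; within the scatter), swaps one group for another on the same aromatic ring and leaves the number essentially unchanged. Compound 3 `COc1cc2c(cc1C)NC(=O)/C2=C/c1c(Cl)n(Cc2cc(OC)c(OC)c(OC)c2)c2cc(C)c(OC)cc12` gives 16600 nM, the highest of the three numbers, and it stands well apart from both compound 1 and compound 2.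

Compound 4 `COc1ccc2c(c1)/C(=C\c1c(Cl)n(Cc3cc(OC)c(OC)c(OC)c3)c3cc(C)c(OC)cc13)C(=O)N2` differs from compound 3 by hydrogen in place of methyl on an aromatic carbon. Within the data shown here, no measured step removes a methyl from this ring; the only step available concerns a different group at another carbon of the same ring and stayed within the scatter. There is therefore no direct guide, and the reasonable expectation is a step of little or no size beyond the scatter, with the direction uncertain. Compound 4 is estimated to give 16000 nM, within a range from 6000 nM to 45000 nM. This estimate means an expected step of a 1.0-fold lower number from compound 3 to compound 4 (0.02 log units; within the scatter).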

Compound 4, concentration for 50% growth inhibition: 11000 nM
Compound 4: the middle estimate sits 1.5-fold (0.16 log units) above what was measured; measured number inside the range.
By their numbers in this assay, from the lowest: compounds 2 and 1 (each within the scatter of the next); then compounds 4 and 3 (each within the scatter of the next).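

In this assay, taking the methyl off this ring, at the carbon ortho to a methoxy group, gives a step that stays within the scatter (a 1.5-fold lower number from compound 3 to compound 4 (0.18 log units; within the scatter)), so this methyl can go without a change that these numbers can resolve. Compound 4 also shows that the group at the other carbon of this ring matters more, since methoxy gives a modest step beyond the scatter, both against chloro (a 5.0-fold higher number from compound 2 to compound 4 (0.70 log units; beyond the scatter)) and against hydroxy (a 4.8-fold higher number from compound 1 to compound 4 (0.68 log units; beyond the scatter)). No measurement is at hand to explain these steps.

On these data alone, it remains open whether a larger group, such as an ethyl group or a longer chain, would be tolerated where the methyl sat. An amine or a carboxylic acid on this ring is also untested among the compounds shown here.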